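The source may hold more compounds than are shown below. What is called first, only, known or untested is meant among the compounds shown, and "the series" means these compounds.

Among the measured compounds shown here, compound 2 `O=C1OC(c2ccccc2)CN1c1cnn2c1CN(C(=O)Nc1cc(F)c(F)c(F)c1)C(C1CC1)C2` gives 7410 nM in a toxicity assay on HepG2 2.2.15 cells (Homo sapiens) for cytotoxicity, read by CellTiter-Glo (on this read-out lower numbers stand for higher toxicity in this test and higher numbers for lower toxicity in this test), the lowest of the three numbers measured so far: compound 1 `O=C1NC(c2ccccc2)CN1c1cnn2c1CN(C(=O)Nc1cc(F)c(F)c(F)c1)C(C1CC1)C2` gives 38500 nM and compound 3 `O=C1CC(c2ccc(F)cn2)CN1c1cnn2c1CN(C(=O)Nc1cc(F)c(F)c(F)c1)C(C1CC1)C2` gives 38500 nM. Compound 4 `O=C1CC(c2ccccn2)CN1c1cnn2c1CN(C(=O)Nc1cc(F)c(F)c(F)c1)C(C1CC1)C2` carries 2-oxo-4-(pyridin-2-yl)pyrrolidin-1-yl in place of 2-oxo-5-phenyl-1,3-oxazolidin-3-yl on an aromatic carbon. For the measured compounds named here, only one measured step touches this place, a 5.2-fold lower number from compound 1 to compound 2 (0.72 log units; beyond the scatter), and it shows that exchanging the five-membered non-aromatic ring there can move the number beyond the scatter. Going by the values given here, compound 3, whose group at this place resembles the one entering compound 4, gives a higher number than compound 2, although no single step links those two. The step to compound 4 is therefore expected to be upward, a 4.0-fold higher number from compound 2 to compound 4 (0.61 log units; beyond the scatter). Compound 4 is estimated at 30000 nM, within 10000 nM to 70000 nM.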

Compound 4, half-maximal cytotoxic concentration: 96200 nM
For compound 4 the middle estimate is 3.2-fold (0.51 log units) below the measured one, and the stated range ends below it.
By their numbers in this assay, from the lowest: compound 2; then compounds 1 and 3 (each within the scatter of the next); then compound 4.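

In this assay, 2-oxo-4-(pyridin-2-yl)pyrrolidin-1-yl moves the number further than any earlier exchange at this place, with a 13-fold higher number from compound 2 to compound 4 (1.11 log units; beyond the scatter). It also exceeds the 2-oxo-4-phenylimidazolidin-1-yl group, with a 2.5-fold higher number from compound 1 to compound 4 (0.40 log units; beyond the scatter). The outer aromatic ring matters as well, since removing only the fluoro gives a 2.5-fold higher number from compound 3 to compound 4 (0.40 log units; beyond the scatter).

No measurement available here explains these shifts. The compounds shown leave open how chloro or methoxy in place of that fluoro would change the number.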